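Taking one acetyl from compound 3

The source may report more compounds than this note shows. Statements on the series, on what has been measured and on what is new or still open speak of the compounds shown alone.

Measured in a functional assay on K562 cells (Homo sapiens) for cytotoxicity, read by spectrophotometry; on this read-out lower numbers stand for stronger inhibition and higher numbers for weaker inhibition:
- compound 1 `CC(=O)O[C@@H](C[C@@H]1C(C)=CCC(=O)C1(C)C)/C(C)=C/[C@@H](C/C=C(\C)CC[C@H]1C(C)(C)[C@@H](O[C@@H]2O[C@H](CO)[C@H](O)[C@H](O)[C@H]2O)CC[C@]1(C)OC(C)=O)OC(C)=O`: 17000 nM
- compound 2 `CC(=O)O[C@@]1(C)CC[C@H](O)C(C)(C)[C@@H]1CC/C(C)=C/C[C@@H](O)/C=C(\C)[C@@H](O)C[C@@H]1C(C)=CCC(=O)C1(C)C`: 14800 nM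
- compound 3 `CC(=O)O[C@@H](C[C@@H]1C(C)=CCC(=O)C1(C)C)/C(C)=C/[C@@H](C/C=C(\C)CC[C@H]1C(C)(C)[C@@H](O)CC[C@]1(C)OC(C)=O)OC(C)=O`: 38900 nM

Of these three, compound 3 shows the highest number, 38900 nM, and so the weakest inhibition. Compound 4 `CC(=O)O[C@@H](C[C@@H]1C(C)=CCC(=O)C1(C)C)/C(C)=C/[C@H](O)C/C=C(\C)CC[C@H]1C(C)(C)[C@@H](O)CC[C@]1(C)OC(C)=O` differs from it by one change hydrogen in place of acetyl on an oxygen on a saturated carbon, or acetoxy to hydroxy. Going by the values given here, no measured step covers this exact change. The nearest is a 2.3-fold higher number from compound 1 to compound 3 (0.36 log units; beyond the scatter), a modest step that removes a different group, 3,4,5-trihydroxy-6-(hydroxymethyl)oxan-2-yl, so it indicates only a plausible size. Against the more heavily acetylated compound 3, compound 2 carries fewer acetyl groups and gives 14800 nM, which hints at a lower number in this assay. A small move in that direction is therefore expected, estimated as a 1.6-fold lower number from compound 3 to compound 4 (0.19 log units; within the scatter). For compound 4 the estimated value is 25000 nM, with an expected range from 12000 nM to 50000 nM.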

Compound 4, half-maximal inhibitory concentration: 14600 nM
Compound 4: the middle estimate sits 1.7-fold (0.23 log units) above what was measured; low and high end bracket the measured number.
By their numbers in this assay, from the lowest: compounds 4, 2 and 1 (each within the scatter of the next); then compound 3.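

In this assay, going by these compounds alone, taking the acetyl off this oxygen on a saturated carbon counts for something: a 2.7-fold lower number from compound 3 to compound 4 (0.43 log units; beyond the scatter) is beyond the scatter, and it is the first measured step to involve an acetyl rather than the sugar group. The same kind of change at a second oxygen does not repeat the effect, since a 1.0-fold lower number from compound 2 to compound 4 (0.01 log units; within the scatter) stays within the scatter, so among these compounds the effect of an acetyl depends on which oxygen carries it. Nothing in the material given accounts for this difference between the two oxygens.

Still open, on these data alone, is whether the step depends on acetyl itself or would also appear with a methyl ether or a longer acyl chain such as butanoyl on this oxygen. As far as these compounds go, it is also open whether an amine in place of the hydroxy would keep the value of compound 4.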